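The source may report more compounds than this note shows. Statements on the series, on what has been measured and on what is new or still open speak of the compounds shown alone.

Compound 1 `O=C(CCCCOc1ccccc1)OCC1COCCOCCOCCOCCOCCO1` carries a crown-type core bearing an ester side chain. In a functional assay on HeLa cells (Homo sapiens) for inhibition, read by sulforhodamine B assay, with a stated time of 48 h (on this read-out lower numbers stand for stronger inhibition of growth and higher numbers for weaker inhibition of growth), compound 1 gives only a limit of the assay, > 100000 nM, and no number. Compound 2 `O=C(OCC1COCCOCCOCCOCCOCCO1)c1cccc(-c2ccc(Br)cc2)c1` gives 7800 nM in this assay. Compound 3 `O=C(CCCc1cc2ccccc2[nH]1)OCC1COCCOCCOCCOCCOCCO1` arises from compound 1 by one change: 1H-indol-2-yl in place of phenoxymethyl on a saturated chain carbon, three bonds along the chain from a carbonyl carbon. Because compound 1 sits at the limit of > 100000 nM in this assay, at which 1 of the 2 values shown sits, the step to compound 3 can only be read as a move off that limit, and the step of an at least 1.6-fold lower number from compound 1 to compound 3 (0.22 log units; that floor lies within the scatter) is expected to be modest, toward stronger inhibition. Compound 3 is therefore estimated at 60000 nM, within 15000 nM to 250000 nM.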

Compound 3, concentration for 50% growth inhibition: > 100000 nM
Compound 3: a limit, no number (the forecaster's own chance of this, stated with the estimate: 55%); middle value at least 1.6-fold (0.22 log units) away from the limit.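

Compound 3, like compound 1, gives only a limit and no number, so no step between them can be read: the limit of > 100000 nM in this assay, at which 2 of the 3 values shown sit.

The compounds shown leave open whether 1H-indol-2-yl in place of phenoxymethyl shifts the result in this assay at all.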